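Hydroxy on the Benzylidene Arm: What to Expect

This account rests on a few compounds, and the source may have more. Where it says the series, first, only, none or still open, it means among the compounds named here.

Measured so far in a functional assay on the whole organism (strain Charles-Foster albino) for inhibition, with Rattus norvegicus as the target, read by paw edema, at a dose of 50 mg/kg by the oral route; a lower number here means less inhibition, a higher number more inhibition at the dose given (going by the name of the read-out):
compound 1, `O=C1CSC(c2ccccc2)N1n1c(CSc2nnc(-c3ccncc3)o2)nc2ccc(Br)cc2c1=O`, 31.3%
compound 2, `O=c1c2cc(Br)ccc2nc(CSc2nnc(-c3ccncc3)o2)n1/N=C/c1ccccc1`, 19.4%

Among the measured compounds shown here, compound 2 stands at the bottom of these two numbers; its only neighbour is compound 1, and the step of a number 11.9 percentage points lower from compound 1 to compound 2 (beyond the scatter) swapped the ring-bearing group on the aromatic nitrogen. That step is the whole of what has been measured, and it concerns a different part of the molecule from the change now in question.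

Compound 3, `O=c1c2cc(Br)ccc2nc(CSc2nnc(-c3ccncc3)o2)n1/N=C/c1ccc(O)cc1`, keeps everything of compound 2 and adds one change: hydroxy in place of hydrogen on an aromatic carbon. For the measured compounds named here, no measured step touches this phenyl ring, so there is nothing in the numbers that speaks for a rise or a fall. Going by the values given here, the one step on record, a number 11.9 percentage points lower from compound 1 to compound 2 (beyond the scatter), was of modest size and on another site, so it gives only a sense of how much a single change moved the read-out.

With no guide, the expected step of a number 2.6 percentage points higher from compound 2 to compound 3 (within the scatter) is none beyond the scatter; compound 3 is estimated at 22%, in the range 10% to 38%.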

Compound 3, a percentage reported as inhibition, in the whole organism at one dose (the size of the read-out at that dose, not a potency): 22.3%
For compound 3 the middle estimate is 0.3 percentage points below the measured one, and the stated range covers the measured number.
By their numbers in this assay, from the lowest: compounds 2, 3 and 1 (each within the scatter of the next, the first and the last beyond it).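

In this assay, among the compounds shown here, the change from phenyl to 4-hydroxyphenyl is the first one made on this ring, and the step of a number 2.9 percentage points higher from compound 2 to compound 3 (within the scatter) shows that hydroxy in place of hydrogen, on an aromatic carbon para to a large group, leaves the read-out indistinguishable at this dose. The second step, a number 9 percentage points lower from compound 1 to compound 3 (within the scatter), adds that compound 3 cannot be separated from compound 1, although compound 2 can; with compound 2 and compound 3 themselves within the scatter of each other, this contrast carries little weight. No measurement at hand gives a reason for the size of either step.

Still open, from the compounds shown here alone, is whether a methoxy group, an amine or a carboxylic acid at this same place on the ring would give a step beyond the scatter, or whether this position simply has little bearing on the read-out. Going by these compounds, it is also open whether hydroxy would act in the same way on the phenyl ring of compound 1, where the group on the aromatic nitrogen is different.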